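Swapping a Fluoromethoxyphenyl for a Furan on the Amine

The compounds below may be only part of what the source reports. "The series", "measured", "known", "first", "only" and "open" are said of these compounds alone.

Three compounds have been measured in an ADME assay on HepG2 cells (Homo sapiens) for cytotoxicity, read by luminescence, CellTiter-Glo and ATP content, with a stated time of 72 h; a higher number here means that more compound is needed for the effect, a lower number that less compound is needed:

Compound 1 `COc1ccc(Oc2ccc3c(NCCCNCc4cc(F)ccc4OC)ccnc3c2)cc1` gives 7000 nM.
Compound 2 `COc1ccc(F)cc1CNCCCNc1ccnc2cc(CCC(C)C)ccc12` gives 890 nM.
Compound 3 `COc1cccc(Oc2ccc3c(NCCCNCc4cc(F)ccc4OC)ccnc3c2)c1` gives 7100 nM.

Compound 3 gives the highest number of the three, though compound 1 lies within the scatter of it: the step is a 1.0-fold higher number from compound 1 to compound 3 (0.01 log units; within the scatter). Compound 2, carrying isopentyl on the shared core instead of an aryloxy group, stands clearly apart: a 7.9-fold lower number from compound 1 to compound 2 (0.90 log units; beyond the scatter) and an 8.0-fold higher number from compound 2 to compound 3 (0.90 log units; beyond the scatter).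

Compound 4 `COc1cccc(Oc2ccc3c(NCCCNCc4ccco4)ccnc3c2)c1` differs from compound 3 at a different spot. furan-2-yl in place of 5-fluoro-2-methoxyphenyl on a saturated chain carbon bound to an amine nitrogen

Within the data shown here, none of the measured steps touches this position; all three concern the group on the aromatic carbon of the core, and the amine side chain is the same throughout. The step from compound 1 to compound 3 shows that a change elsewhere in the molecule can leave the number unmoved, but nothing measured here speaks to this particular exchange. The expectation is therefore a step within the scatter in this assay, with wide uncertainty: a 1.2-fold lower number from compound 3 to compound 4 (0.07 log units; within the scatter). Compound 4 is estimated at 6000 nM, with a range from 2000 nM to 20000 nM.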

Compound 4, half-maximal effective concentration: 15500 nM
The estimate for compound 4 lay 2.6-fold (0.41 log units) below the measured number, and the stated range covers the measured number.
By their numbers in this assay, from the lowest: compound 2; then compounds 1 and 3 (each within the scatter of the next); then compound 4.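

Among these compounds, until now the amine side chain was the same in every compound, so this is the first reading of that position in this assay. Placing furan-2-yl where 5-fluoro-2-methoxyphenyl stood, on a saturated chain carbon bound to an amine nitrogen, gives a modest change (a 2.2-fold higher number from compound 3 to compound 4 (0.34 log units; beyond the scatter)), which shows that the group here can shift the number even though the rest of the molecule is untouched, and that this exchange, to a group of 5 heavy atoms from one of 9, goes with more compound being needed for the effect. No available evidence accounts for the direction or size of this step.

With a single exchange at this position, the compounds shown cannot separate the effect of the furan ring from the loss of the fluorine or the methoxy group, a question that a plain phenyl, a 2-methoxyphenyl or a thiophene ring at the same place would address. On these data alone, it also remains open whether furan-2-yl would move the number similarly in a compound with isopentyl or 4-methoxyphenoxy on the shared core.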